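The compounds below may be only part of what the source reports. "The series", "measured", "known", "first", "only" and "open" are said of these compounds alone.

In a functional assay on AGS cells (Homo sapiens) for inhibition, read by reporter gene assay (on this read-out higher numbers stand for weaker inhibition and lower numbers for stronger inhibition), compound 3 `CC(=O)c1ccc(OCC(=O)Nc2cccc(C(=O)O)c2)cc1` gives > 30000 nM and this is a limit, not a number. Compound 1 `O=C(COc1ccccc1)Nc1cccc(C(=O)O)c1` gives > 30000 nM and this is also a limit. Compound 2 `Cc1ccc(OCC(=O)Nc2cccc(C(=O)O)c2)cc1` gives > 30000 nM and this is again a limit. For the measured compounds named here, the series so far comes down to the limit of > 30000 nM in this assay, at which 3 of the 3 values shown sit, and no measured number is available yet.

Compound 4 `O=C(COc1ccc(Br)cc1)Nc1cccc(C(=O)O)c1` has bromo in place of acetyl on an aromatic carbon, para to a large group (bromo in place of acetyl on an aromatic carbon) and is otherwise the same as compound 3.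

The steps bearing on this change are a step that the two limits leave unreadable from compound 1 to compound 2 and a step that the two limits leave unreadable from compound 1 to compound 3 and a step that the two limits leave unreadable from compound 2 to compound 3 and none of them offers a size to carry over. Only a small move toward stronger inhibition, if any, is therefore expected in this assay for this exchange. The expected outcome is an at least 1.2-fold lower number from compound 3 to compound 4 (0.07 log units; that floor lies within the scatter) and it carries little confidence. For compound 4 the estimated value is 25000 nM with an expected range from 6000 nM to 60000 nM and a report of only a limit is the likelier result.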

Compound 4, half-maximal inhibitory concentration: 1600 nM
For compound 4 the middle estimate is 16-fold (1.19 log units) above the measured one; the measured number lies below the stated range.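

In this assay, for the compounds shown here, acetyl replaced by bromo on the aromatic carbon para to a large group gives an at least 18-fold lower number from compound 3 to compound 4 (1.27 log units; beyond the scatter), the first sign that a change at this position can register in the read-out. Bromo in place of methyl gives an at least 18-fold lower number from compound 2 to compound 4 (1.27 log units; beyond the scatter), and bromo in place of hydrogen gives an at least 18-fold lower number from compound 1 to compound 4 (1.27 log units; beyond the scatter), whereas the steps among compound 1, compound 2 and compound 3 cannot be read. Compound 4 therefore stands alone with a measured number, and the other compounds remain at a limit: the limit of > 30000 nM in this assay, at which 3 of the 4 values shown sit.

As far as these compounds go, whether chloro, iodo or trifluoromethyl at this position would match bromo remains open. From the compounds shown here alone, all three steps are floors, so their true sizes are unknown, and the effect of bromo on another carbon of this ring also remains open.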